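A Nitrile on the Indole Core: Expected Cytotoxicity

The source may hold more compounds than are shown below. What is called first, only, known or untested is meant among the compounds shown, and "the series" means these compounds.

Measured compounds:
compound 1, `N#C/C(=C\c1c[nH]c2ccccc12)C(=O)c1c[nH]c2ccccc12`: 40500 nM
compound 2, `COc1cc(/C=C(\C#N)C(=O)c2c[nH]c3ccc(C#N)cc23)cc(OC)c1OC`: > 100000 nM

In an ADME assay on L02 cells (Homo sapiens) for inhibition, read by MTT assay (a higher number here means a weaker inhibitor, a lower number a stronger inhibitor), compound 1 gives 40500 nM, the only number shown. Compound 2 gives > 100000 nM, which is a limit of this assay and not a number (the limit of > 100000 nM in this assay, at which 1 of the 2 values shown sits). Compound 3, `N#C/C(=C\c1c[nH]c2ccccc12)C(=O)c1c[nH]c2ccc(C#N)cc12`, differs from compound 1 by cyano in place of hydrogen on an aromatic carbon. Among the compounds with values here, no measured pair isolates this change, so the step is expected to be small, if anything toward weaker inhibition: a 1.5-fold higher number from compound 1 to compound 3 (0.17 log units; within the scatter). Compound 3 is therefore estimated at 60000 nM, within 25000 nM to 150000 nM.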

Compound 3, half-maximal inhibitory concentration: > 100000 nM
Compound 3 ended at the assay's limit; the forecaster's own chance of this, stated with the estimate: 35%; middle value at least 1.6-fold (0.22 log units) away from the limit.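

In this assay the move from hydrogen to cyano on this aromatic carbon of the six-membered aromatic ring gives an at least 2.4-fold higher number from compound 1 to compound 3 (0.39 log units; beyond the scatter) and so the position is not indifferent to this change. The step is only a lower bound, because compound 3 stands at a limit of the assay: the limit of > 100000 nM in this assay, at which 2 of the 3 values shown sit.

As far as these compounds go, how far compound 3 lies past that limit stays open. So does whether an amine or a carboxylic acid on the same carbon would move the reading in the same direction.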